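Methyl versus hydrogen on the pyrrole nitrogen of bromopyrrole chalcones

This account rests on a few compounds, and the source may have more. Where it says the series, first, only, none or still open, it means among the compounds named here.

Measured so far in a functional assay on KB403 cells (Homo sapiens) for cytotoxicity, read by MTT assay, with stated times of 6 h and 48 h; a higher number here means a weaker inhibitor, a lower number a stronger inhibitor:
compound 1 `Cn1c(/C=C/C(=O)c2ccccc2O)cc(Br)c1Br`: 8320 nM
compound 2 `COc1ccc(C(=O)/C=C/c2cc(Br)c(Br)n2C)c(OC)c1`: >= 100000 nM
compound 3 `O=C(/C=C/c1cc(Br)c(Br)[nH]1)c1ccccc1O`: >= 100000 nM

For the measured compounds named here, compound 1 is the only member with a number. For compound 2 the value given is a limit of this assay, not a number. For compound 3 the value is likewise a limit. Two of the three values therefore sit at the same limit (the limit of >= 100000 nM in this assay, at which 2 of the 3 values shown sit).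

Compound 1 and compound 3 differ by hydrogen in place of methyl on an aromatic nitrogen; this change gives an at least 12-fold higher number from compound 1 to compound 3 (1.07 log units; beyond the scatter). How the core of compound 2 differs from that of compound 1 is not broken down here.

Compound 4 `COc1ccc(C(=O)/C=C/c2cc(Br)c(Br)[nH]2)c(OC)c1` is not yet measured. It stands to compound 2 as compound 3 stands to compound 1: hydrogen in place of methyl on an aromatic nitrogen, the same change at the same place. Since compound 2 already gives a limit and the same change on compound 1 raised the number well beyond the scatter, compound 4 is expected to give a limit as well, with an estimated step that the limit leaves unreadable from compound 2 to compound 4. The estimate for compound 4 in this assay is 150000 nM, between 100000 nM and 400000 nM.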

Compound 4, half-maximal inhibitory concentration: >= 100000 nM
Compound 4: no number, only a limit; the forecaster's own chance of this, stated with the estimate: 85%; the middle value lies beyond the limit too.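

Compound 2 and compound 4 both give only a limit in this assay, not a number, so hydrogen in place of methyl on the aromatic nitrogen yields no readable step for this pair: the limit of >= 100000 nM in this assay, at which 3 of the 4 values shown sit.

The compounds shown leave open whether this change alters the number at all on the core of compound 2, as it does on the core of compound 1.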